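Swapping a six-membered ring for a five-membered one

This account rests on a few compounds, and the source may have more. Where it says the series, first, only, none or still open, it means among the compounds named here.

Among the measured compounds shown here, in an ADME assay on HOS cells (Homo sapiens) for cytotoxicity (a higher number here means that more compound is tolerated, a lower number that less compound is tolerated), compound 1 `CN1CCC(n2c(CN(C)C3CCCc4cccnc43)nc3ccccc32)CC1` gives 16000 nM, the highest of the three numbers measured so far. Compound 2 `CN(Cc1nc2ccccc2n1CC1CCNC1)C1CCCc2cccnc21` gives 7700 nM, and compound 3 `CN1CCC[C@@H](Cn2c(CN(C)[C@@H]3CCCc4cccnc43)nc3ccccc32)C1` gives 2800 nM. Compound 4 `CN1CCC(Cn2c(CN(C)C3CCCc4cccnc43)nc3ccccc32)C1` is still unmeasured. It has the same atoms as compound 1, joined differently, with (1-methylpyrrolidin-3-yl)methyl in place of 1-methylpiperidin-4-yl on an aromatic nitrogen. The closest measured change is a 2.1-fold lower number from compound 1 to compound 2 (0.32 log units; beyond the scatter). That modest step brings in (pyrrolidin-3-yl)methyl, the same group without its methyl. A step in the same direction and of similar size is expected here, a 2.7-fold lower number from compound 1 to compound 4 (0.43 log units; beyond the scatter). Compound 4 is therefore estimated at 6000 nM, with an expected range of 2500 nM to 13000 nM.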

Compound 4, half-maximal cytotoxic concentration: 15000 nM
The estimate for compound 4 lay 2.5-fold (0.40 log units) below the measured number, outside the stated range (above it).
By their numbers in this assay, from the lowest: compound 3; then compounds 2, 4 and 1 (each within the scatter of the next, the first and the last beyond it).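

In this assay this position shows little response to the ring swap: replacing 1-methylpiperidin-4-yl with (1-methylpyrrolidin-3-yl)methyl gives a 1.1-fold lower number from compound 1 to compound 4 (0.03 log units; within the scatter) and stays level. Methyl in place of hydrogen on the ring amine nitrogen also stays within the scatter, with a 1.9-fold higher number from compound 2 to compound 4 (0.29 log units; within the scatter) as its step, so neither change alone accounts for a 2.1-fold lower number from compound 1 to compound 2 (0.32 log units; beyond the scatter) and each is small when read by itself. No available measurement explains these numbers. Still open, from the compounds shown here alone, is whether ethyl or acetyl on that ring nitrogen, or a cyclohexyl ring without nitrogen, would shift the number.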